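Exchanging the Benzyl Group of Compound 3: What to Expect

The source may report more compounds than this note shows. Statements on the series, on what has been measured and on what is new or still open speak of the compounds shown alone.

Measured compounds:
Compound 1, `CSCC[C@H](NC(=O)c1ccc(NCc2cncn2Cc2ccc([N+](=O)[O-])cc2)cc1-c1ccccc1)C(=O)O`: in a functional assay on NIH3T3 cells (Mus musculus) (on this read-out lower numbers stand for an effect already at smaller amounts and higher numbers for an effect only at larger amounts of compound), compound 1 gives > 10 uM, which is a limit of the assay, not a number.
Compound 2, `COC(=O)[C@H](CCSC)NC(=O)c1ccc(NCc2cncn2Cc2ccccc2C#N)cc1-c1ccccc1`: in this assay compound 2 gives > 10 uM, again only a limit.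
Compound 3, `COC(=O)[C@H](CCSC)NC(=O)c1ccc(NCc2cncn2Cc2cccc(C#N)c2)cc1-c1ccccc1`: in this assay compound 3 gives > 10 uM, once more a limit.

Within the data shown here, compound 3 therefore stands at the limit of > 10 uM in this assay, at which 3 of the 3 values shown sit; no compound in this set has a measured number, and the single one-place step, a step that the two limits leave unreadable from compound 2 to compound 3, cannot be read for that reason.

The new compound 4 is `COC(=O)[C@H](CCSC)NC(=O)c1ccc(NCc2cncn2Cc2ccc([N+](=O)[O-])cc2)cc1-c1ccccc1`. It differs from compound 3 as follows: 4-nitrophenyl in place of 3-cyanophenyl on a saturated chain carbon bound to an aromatic nitrogen.

Among the measured compounds shown here, the only measured step at this place is a step that the two limits leave unreadable from compound 2 to compound 3, and it gives no readable size, so nothing quantitative can be carried over. The same 4-nitrophenyl group that enters compound 4 is also carried by compound 1, and compound 1 shows > 10 uM, a limit. On this basis compound 4 is expected to remain at the limit as well, with an estimated value of 20 uM (range 5 uM to 80 uM). The expected step that the limit leaves unreadable from compound 3 to compound 4 is therefore estimated to be none that the assay can resolve.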

Compound 4, concentration for half-maximal effect: > 10 uM
Compound 4 was reported as a limit (the forecaster's own chance of this, stated with the estimate: 80%); the middle value lies beyond the limit too.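

No step from compound 1, compound 2 or compound 3 to compound 4 can be read, because all of them sit at the same limit, which is not a number: the limit of > 10 uM in this assay, at which 4 of the 4 values shown sit.

The compounds shown leave open whether exchanging the benzyl group, or methyl in place of hydrogen on the oxygen, changes the effect at all, and by how much.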